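Two anilino analogues at the assay limit, a methyl congener ahead

This account rests on a few compounds, and the source may have more. Where it says the series, first, only, none or still open, it means among the compounds named here.

Compound 1 `O=[N+]([O-])c1ccc(Nc2nc3c(N4CCCC4)ncnc3s2)cc1`: > 30000 nM
Compound 2 `Clc1ccc(Nc2nc3c(N4CCCC4)ncnc3s2)cc1`: > 100000 nM

Compound 1 `O=[N+]([O-])c1ccc(Nc2nc3c(N4CCCC4)ncnc3s2)cc1` carries a nitro group on the anilino ring, and in an assay on CHO cells for displacement of a labelled ligand from adenosine receptor A1 (Homo sapiens), read by scintillation counting, with a stated time of 3 h (on this read-out higher numbers stand for weaker inhibition and lower numbers for stronger inhibition), compound 1 gives > 30000 nM, which is a limit of the assay rather than a number. Compound 2 `Clc1ccc(Nc2nc3c(N4CCCC4)ncnc3s2)cc1` carries a chloro group in the same position, and in this assay compound 2 gives > 100000 nM, again a limit. Compound 2 therefore stands at the weak end of what the assay can report. The step that the two limits leave unreadable from compound 1 to compound 2 cannot be sized. Compound 1 sits at the limit of > 30000 nM in this assay, at which 1 of the 2 values shown sits. Compound 2 sits at the limit of > 100000 nM in this assay, at which 1 of the 2 values shown sits.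

Compound 3 `Cc1ccc(Nc2nc3c(N4CCCC4)ncnc3s2)cc1` differs from compound 2 by methyl in place of chloro on an aromatic carbon. For the measured compounds named here, the only measured step does not bear a readable size, so no direction can be taken from it. With both anilino analogues at a limit, compound 3 is expected to remain there as well, and the expected step of a number no higher from compound 2 to compound 3 (the limit leaves the size open) is none beyond the scatter. For compound 3 the estimate in this assay is 100000 nM, between 30000 nM and 300000 nM.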

Compound 3, inhibition constant: > 100000 nM
Compound 3 gave a limit, no number; the forecaster's own chance of this, stated with the estimate: 80%; the middle value sits exactly at the limit.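

In this assay compound 3 gives > 100000 nM, which is a limit of the assay and not a number. No new step can be read, either from compound 2 to compound 3 or from compound 1 to compound 3. The compounds shown leave open whether any group in this position gives a measurable value in this assay.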